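A few compounds are considered here, and "the series" means these few. Any claim that something is new, unique, unknown or untested is made for them only; others in the source may bear on it.

Compound 1, `CCN(CC)CCCOc1cc(OC)ccc1-c1cc(-c2ccccc2)no1`, in a functional assay on the whole organism (blood, strain Sprague-Dawley albino) with Rattus norvegicus as the target, with stated times of 30 min and 24 h, at a dose of 100 mg/kg by the oral route (a lower number here means less inhibition, a higher number more inhibition at the dose given (going by the name of the read-out)), gives 9.2%. Compound 2, `COc1ccc(-c2cc(-c3ccccc3)no2)c(OCCCN2CCCCC2)c1`, in this assay gives 15%.

On these two numbers compound 2 stands together with compound 1: the step of a number 5.8 percentage points higher from compound 1 to compound 2 (within the scatter), and so the two are not separated by the scatter. Compound 3, `COc1ccc(-c2cc(-c3ccccc3)no2)c(OCC(O)CN2CCCCC2)c1`, differs from compound 2 by hydroxy in place of hydrogen on a saturated chain carbon bound to two saturated chain carbons. Within the data shown here, no measured step touches this kind of change; the only step at hand, from diethylamino to piperidin-1-yl, lies at another place and was within the scatter. Compound 3 is therefore expected to sit near compound 2, with an expected step of a number 3 percentage points lower from compound 2 to compound 3 (within the scatter) that does not exceed the scatter. The estimate for compound 3 is 12%, between 2% and 30%.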

Compound 3, a percentage reported as inhibition, in the whole organism at one dose (the size of the read-out at that dose, not a potency): 16.8%
Compound 3: the middle estimate sits 4.8 percentage points below what was measured; the measured number falls inside the stated range.
By their numbers in this assay, from the lowest: compounds 1, 2 and 3 (each within the scatter of the next).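

Hydroxy in place of hydrogen on a saturated chain carbon bound to two saturated chain carbons gives a number 1.8 percentage points higher from compound 2 to compound 3 (within the scatter) in this assay and so, at this first change on the chain itself, does not separate the two compounds. The wider change, 1-hydroxy-2-(piperidin-1-yl)ethyl in place of 2-(diethylamino)ethyl, gives a number 7.6 percentage points higher from compound 1 to compound 3 (within the scatter) and separates nothing either. No evidence at hand speaks to these numbers.

As far as these compounds go, whether an amine, a fluorine or a carboxylic acid on this chain carbon would give a step beyond the scatter stays open. So does the effect of a longer chain.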